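The source may report more compounds than this note shows. Statements on the series, on what has been measured and on what is new or still open speak of the compounds shown alone.

Series notes. Going by the values given here, compound 3 `Cc1nn(C)c(Oc2ccc(Cl)cc2)c1/C=N\CCCCCCOc1cc2oc(=O)cc(C)c2cc1Cl` is the only member with an actual number in a functional assay on HepG2 cells (Homo sapiens) for antiproliferative activity, read by MTT assay, with a stated time of 72 h; a lower number here means a stronger inhibitor, a higher number a weaker inhibitor: compound 3 gives 2960 nM. Compound 1 `Cc1nn(C)c(Oc2cccc(F)c2F)c1/C=N\CCCCCCOc1cc2oc(=O)cc(C)c2cc1Cl` gives only a limit in this assay, > 25000 nM. Compound 2 `Cc1nn(C)c(Oc2ccc(F)c(F)c2)c1/C=N\CCCCCCOc1cc2oc(=O)cc(C)c2cc1Cl` likewise gives only a limit in this assay, > 25000 nM. The step that the two limits leave unreadable from compound 1 to compound 2 accordingly cannot be read from the two limits. The steps of an at least 8.4-fold lower number from compound 1 to compound 3 (0.92 log units; beyond the scatter) and an at least 8.4-fold lower number from compound 2 to compound 3 (0.92 log units; beyond the scatter) are both bounded on the weak side by the limit of > 25000 nM in this assay, at which 2 of the 3 values shown sit, so their true size is only known as a minimum.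

Compound 4 `Cc1nn(C)c(Oc2ccc(I)cc2)c1/C=N\CCCCCCOc1cc2oc(=O)cc(C)c2cc1Cl` differs from compound 3 by iodo in place of chloro on an aromatic carbon. Among the compounds with values here, none of the measured steps exchanges one halogen for another on the phenoxy group; each replaces a difluorophenyl with the 4-chlorophenyl, and together they show only that the 4-chlorophenoxy member is the sole one with a readable value. Within the data shown here, no measured step speaks to the size or direction of a chloro-to-iodo exchange. The expectation for compound 4 in this assay is therefore a step of a 1.2-fold lower number from compound 3 to compound 4 (0.07 log units; within the scatter), within the scatter, with no direction that can be defended from the data shown. Compound 4 is estimated at 2500 nM in this assay, with a range from 700 nM to 9000 nM.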

Compound 4, half-maximal inhibitory concentration: 14200 nM
Compound 4: the middle estimate sits 5.7-fold (0.75 log units) below what was measured; the whole stated range lies below it.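

In this assay, going by these compounds alone, the exchange of chloro for iodo on the phenoxy group gives a 4.8-fold higher number from compound 3 to compound 4 (0.68 log units; beyond the scatter), the first step that changes only the halogen at this place, and it shows that the identity of that halogen alone moves the value beyond the scatter. Against the difluorophenyl members, the steps are an at least 1.7-fold lower number from compound 2 to compound 4 (0.24 log units; that floor lies within the scatter) and an at least 1.7-fold lower number from compound 1 to compound 4 (0.24 log units; that floor lies within the scatter); since those floors lie within the scatter, they do not establish how far the 4-iodophenyl member stands from either, and their true size is known only as a minimum: the limit of > 25000 nM in this assay, at which 2 of the 4 values shown sit. Among the four compounds, compound 3 is now the strongest, with all its steps printed as beyond the scatter, so a single halogen at this place does not by itself fix the value.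

Whether a 4-bromophenyl or 4-fluorophenyl member would fall between compound 3 and compound 4 stays open, and these compounds give no cause for the chloro-to-iodo step. Also open, as far as these compounds go, is whether the same exchange would carry over with a non-halogen group at this place, such as methoxy or an amine, or with a longer chain.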